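Cyano-to-methyl swap on the diaryl ether and diamine cores

A few compounds are considered here, and "the series" means these few. Any claim that something is new, unique, unknown or untested is made for them only; others in the source may bear on it.

Measured in a physicochemical assay for lipophilicity; on this read-out higher numbers stand for higher lipophilicity and lower numbers for lower lipophilicity:
- compound 1, `Cc1cc(C#N)cc(C)c1Oc1ccnc(Nc2ccc(C#N)cc2)n1`: 1.64
- compound 2, `Cc1cc(C)c(Oc2ccnc(Nc3ccc(C#N)cc3)n2)c(C)c1`: 2.07
- compound 3, `Cc1cnc(Nc2ccc(C#N)cc2)nc1Nc1c(C)cc(C#N)cc1C`: 1.74

Compound 1 and compound 2 differ in one place, (methyl in place of cyano on an aromatic carbon). On this assay the step is a number 0.43 log units higher from compound 1 to compound 2 (beyond the scatter). Compound 3 carries the core with two anilino links instead of the ether of compound 1; the difference between the two cores is not broken down here. Compound 3 and compound 1 give numbers within the scatter of each other, so no order between them is read; compound 2 stands higher than both.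

Compound 4, `Cc1cc(C)c(Nc2nc(Nc3ccc(C#N)cc3)ncc2C)c(C)c1`, is not yet measured. It differs from compound 3 by methyl in place of cyano on an aromatic carbon. The place description is the same word for word as that of the change from compound 1 to compound 2, so this is the same change, made a second time on a different core.

Among the compounds with values here, for this assay the expectation for compound 4 rests on the measured pair, because a number 0.43 log units higher from compound 1 to compound 2 (beyond the scatter) is the only instance of this change with a number; compound 3 is the starting point. The step from compound 3 to compound 4 is estimated at a number 0.41 log units higher from compound 3 to compound 4 (beyond the scatter), assuming the second core carries the change much as the first did. Compound 4 is accordingly expected to land near 2.15, with a plausible range from 1.85 to 2.45. On these data alone, whether the two cores carry this change alike is untested; one pair cannot settle it.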

Compound 4, partition coefficient: 2.17
Beside the measured number, compound 4's estimate is 0.02 log units below it; measured number inside the range.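

In this assay, methyl in place of cyano on an aromatic carbon gives a number 0.43 log units higher from compound 3 to compound 4 (beyond the scatter), and on the other core the same change gives a number 0.43 log units higher from compound 1 to compound 2 (beyond the scatter), so the two printed steps are the same size and both lie beyond the scatter. For this series, this shows that the change carried over from one core to the other with its size intact, so the step measured on the first core would have served as a fair guide on the second; it does not show that the same would hold on a third core, for another replacement at this place, or on any read-out other than this assay, since the whole case rests on two pairs. No measured information bears on why the two cores give the same step.

The compounds shown leave open how other groups at this place on the aromatic ring would behave, such as an amine, a carboxylic acid or a longer chain like propyl, and whether any of these would also give a step of the same size on both cores. They also leave the effect of the core itself unresolved, as no pair shown differs in the core alone.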